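This account rests on a few compounds, and the source may have more. Where it says the series, first, only, none or still open, it means among the compounds named here.

Compound 1 `CC(=O)N(C)C(C)C#CCn1ccnc1` and compound 2 `CC(=O)N(C)C(C)C#CCn1cncc1C` share one core, and compound 2 carries methyl in place of hydrogen on an aromatic carbon. In a functional assay on the whole organism for antagonist activity, with Mus musculus as the target (a higher number here means that more compound is needed for the effect, a lower number that less compound is needed), compound 1 reaches only a limit of the assay, > 100 mg/kg. In this assay compound 2 gives 1.1 mg/kg. The step of an at least 90-fold lower number from compound 1 to compound 2 (1.95 log units; beyond the scatter) is stated as an at-least figure because of the limit of > 100 mg/kg in this assay, at which 1 of the 3 values shown sits. Compound 3 `CCOC(=O)N(C)CC#CCn1ccnc1` has a different core; the difference between the two cores is not broken down here. In this assay compound 3 gives 97 mg/kg. Compound 4 `CCOC(=O)N(C)CC#CCn1cncc1C` differs from compound 3 by methyl in place of hydrogen on an aromatic carbon, the same change at the same place. On that basis a step of a 49-fold lower number from compound 3 to compound 4 (1.69 log units; beyond the scatter) is expected. Among the compounds with values here, that expectation rests on an at least 90-fold lower number from compound 1 to compound 2 (1.95 log units; beyond the scatter), the only step of this kind seen so far. Compound 4 is therefore estimated at 2 mg/kg, expected to fall between 0.5 mg/kg and 15 mg/kg.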

Compound 4, dose for half-maximal effect: 66 mg/kg
Estimate against measurement, compound 4: 33-fold (1.52 log units) below, outside the stated range (above it).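

On the core of compound 3, methyl in place of hydrogen on an aromatic carbon gives a 1.5-fold lower number from compound 3 to compound 4 (0.17 log units; within the scatter) in this assay, so the large step seen on the other core does not carry over to this one, and the two steps clearly differ: the same change on two cores in this assay, an at least 90-fold lower number (1.95 log units; beyond the scatter) from compound 1 to compound 2 and a 1.5-fold lower number (0.17 log units; within the scatter) from compound 3 to compound 4, at least 61-fold (1.79 log units) apart, beyond the scatter of two such steps. As far as these compounds go, the earlier step gives only a lower bound on its size, so the true gap between the two steps remains unknown: the limit of > 100 mg/kg in this assay, at which 1 of the 4 values shown sits. These two pairs show that the effect of this methyl depends on the core, but they do not show which difference between the cores is responsible or how the change behaves on any further core.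

From the compounds shown here alone, it remains open whether an ethyl group at the same place would follow the methyl on either core. Also open, going by these compounds, is which part of the two cores sets the size of the step.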